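A few compounds are considered here, and "the series" means these few. Any claim that something is new, unique, unknown or untested is made for them only; others in the source may bear on it.

Measured so far in a toxicity assay on HT-29 cells (Homo sapiens) for cytotoxicity; a lower number here means that less compound is tolerated, a higher number that more compound is tolerated:

Compound 1 `CN1C(=S)[C@@H](NC(=O)c2n[nH]c(Cc3ccccc3)n2)COc2ccccc21`: > 50000 nM (a limit)
Compound 2 `CN1C(=S)[C@@H](NC(=O)c2nc(Cc3ccccc3)n(C)n2)COc2ccccc21`: > 100000 nM (a limit)

Compound 2 stands only at a limit, > 100000 nM, and not at a number. Compound 1 likewise gives only a limit, > 50000 nM, and not a number.

The next change leads to compound 3 `CCn1nc(C(=O)N[C@H]2COc3ccccc3N(C)C2=S)nc1Cc1ccccc1`, with methyl in place of hydrogen on a saturated chain carbon bound to an aromatic nitrogen, or methyl to ethyl when cut one bond further out.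

For the measured compounds named here, the only measured step bearing on this is a step that the two limits leave unreadable from compound 1 to compound 2, where methyl takes the place of hydrogen on an aromatic nitrogen. Going by the values given here, it gives no size to carry over, and no measured compound has a number in this assay so far. With compound 2 at the limit > 100000 nM as the only anchor, no step beyond the scatter is expected, and no direction can be given. Compound 3 is expected to report a limit as well.

The expected step is a number no higher from compound 2 to compound 3 (the limit leaves the size open). For compound 3 the estimated value is 100000 nM, with an expected range from 40000 nM to 200000 nM.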

Compound 3, half-maximal cytotoxic concentration: > 100000 nM
Compound 3: no number, only a limit; the forecaster's own chance of this, stated with the estimate: 85%; the middle value lies on the limit itself.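

In this assay compound 3 gives > 100000 nM, a limit and not a number. For the compounds shown here, compound 1, compound 2 and compound 3 all stand at limits, and no step among them can be read. The compounds shown leave open whether hydrogen, methyl or ethyl on the aromatic nitrogen makes any difference in this assay, and in which direction.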